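The source may hold more compounds than are shown below. What is called first, only, known or untested is meant among the compounds shown, and "the series" means these compounds.

Working notes on the series. Compound 3 `c1ccc(-c2n[nH]cc2N2CCNCC2)cc1` is the parent with an unsubstituted phenyl ring. In an assay on isolated protein for binding affinity to 5-hydroxytryptamine receptor 1D (Homo sapiens) (on this read-out higher numbers stand for weaker inhibition and lower numbers for stronger inhibition), compound 3 gives > 10000 nM, which is a limit of the assay rather than a number. Compound 1 `COc1ccccc1-c1n[nH]cc1N1CCNCC1` carries a methoxy group; in this assay compound 1 gives > 10000 nM, again a limit. Compound 2 `COc1ccc(-c2n[nH]cc2N2CCNCC2)cc1` also carries a methoxy group; in this assay compound 2 gives > 10000 nM, likewise a limit. Within the data shown here, compound 3 thus stands where every value so far stands: the limit of > 10000 nM in this assay, at which 3 of the 3 values shown sit.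

The two measured steps that touch compound 3, a step that the two limits leave unreadable from compound 1 to compound 3 and a step that the two limits leave unreadable from compound 2 to compound 3, cannot be read in size, since both ends sit at the limit. The data therefore do not show whether a substituent on this ring shifts the affinity at all.

Compound 4 `Fc1ccccc1-c1n[nH]cc1N1CCNCC1` differs from compound 3 by fluoro in place of hydrogen on an aromatic carbon. Among the measured compounds shown here, no measured step concerns a fluoro group; the two steps that exist involve only a methoxy group and end at the limit on both sides. The step that the limit leaves unreadable from compound 3 to compound 4 is therefore expected to be none beyond the scatter, with the result most likely reported once more only as a limit. Compound 4 is estimated at 15000 nM, within a range from 4000 nM to 60000 nM.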

Compound 4, inhibition constant: > 10000 nM
Compound 4 was reported as a limit; the forecaster's own chance of this, stated with the estimate: 80%; the middle value is on the limit's open side.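

No new step can be read: the comparisons of compound 4 with compound 3 and with compound 1 have a limit at both ends, and the whole series sits at one limit: the limit of > 10000 nM in this assay, at which 4 of the 4 values shown sit. The compounds shown leave open whether fluoro or methoxy on this ring changes the affinity at all.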